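Removing benzyl from compound 3: what to expect

A few compounds are considered here, and "the series" means these few. Any claim that something is new, unique, unknown or untested is made for them only; others in the source may bear on it.

compound 1 `COC(=O)c1c(-c2ccc([N+](=O)[O-])cc2)oc2cc(OC)ccc2c1=O` gives 2.84 ug/mL
compound 2 `COC(=O)c1c(-c2ccc(OCc3ccccc3)cc2)oc2ccccc2c1=O` gives > 25 ug/mL as a limit of the assay
compound 3 `COC(=O)c1c(-c2ccc(OCc3ccccc3)cc2)oc2ccc(OC)cc2c1=O` gives 20.9 ug/mL

In a functional assay on SK-MEL cells (Homo sapiens) for cytotoxicity, read by MTT assay, with a stated time of 6 days (on this read-out higher numbers stand for an effect only at larger amounts of compound and lower numbers for an effect already at smaller amounts), compound 3 has the higher of the two actual numbers (20.9 ug/mL), and compound 1 lies lower (2.84 ug/mL), a gap beyond the usual scatter.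

The next change leads from compound 3 to compound 4 `COC(=O)c1c(-c2ccc(O)cc2)oc2ccc(OC)cc2c1=O` and is hydrogen in place of benzyl on an oxygen on an aromatic ring. Among the measured compounds shown here, the only measured step, an at least 1.1-fold lower number from compound 2 to compound 3 (0.07 log units; that floor lies within the scatter), is a different change, methoxy in place of hydrogen. It offers no size to carry over, so no step beyond the scatter is expected in this assay. The expected step is a 1.2-fold lower number from compound 3 to compound 4 (0.06 log units; within the scatter). For compound 4 the estimated value is 18 ug/mL, with an expected range from 6 ug/mL to 40 ug/mL.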

Compound 4, concentration for half-maximal effect: 18.7 ug/mL
Compound 4: middle estimate off by 1.0-fold (0.02 log units), on the low side, and the stated range covers the measured number.
By their numbers in this assay, from the lowest: compound 1; then compounds 4 and 3 (each within the scatter of the next). At a limit, above all of these: compound 2.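

At this oxygen on an aromatic ring, the whole benzyl group, with its six-membered aromatic ring, can give way to hydrogen with no change beyond the scatter in this assay: a 1.1-fold lower number from compound 3 to compound 4 (0.05 log units; within the scatter). So benzyl is not needed here to keep this level of cytotoxicity. Unlike the earlier step, this one joins two actual numbers, whereas compound 2 stands at a limit: the limit of > 25 ug/mL in this assay, at which 1 of the 4 values shown sits.

As far as these compounds go, whether a longer chain on this oxygen, or one ending in an amine or a carboxylic acid, would shift the number stays open. So does whether hydrogen in place of benzyl would give a similar step on the core of compound 2.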